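Fluoro for chloro on the aryl imine of compound 2

This account rests on a few compounds, and the source may have more. Where it says the series, first, only, none or still open, it means among the compounds named here.

Three measured compounds share one core and differ only in the aryl on the carbon with a double bond to nitrogen: compound 1 `CSc1ccc(/C=N/n2c(Cc3ccc(S(C)(=O)=O)cc3)n[nH]c2=S)cc1`, compound 2 `CS(=O)(=O)c1ccc(Cc2n[nH]c(=S)n2/N=C/c2ccccc2Cl)cc1` and compound 3 `CS(=O)(=O)c1ccc(Cc2n[nH]c(=S)n2/N=C/c2c(F)cccc2Cl)cc1`. In a functional assay on HeLa cells (Homo sapiens) for cytotoxicity, read by MTT assay, with a stated time of 48 h, tested at 12.5 uM (a higher number here means a stronger effect of the compound at the concentration tested, a lower number a weaker effect), compound 1 gives 27.9%, compound 2 gives 34.7% and compound 3 gives 49.8%. Compound 2 stands second of the three: the step of a number 6.8 percentage points higher from compound 1 to compound 2 (within the scatter) is within the scatter, whereas a number 15.1 percentage points higher from compound 2 to compound 3 (beyond the scatter) and a number 21.9 percentage points higher from compound 1 to compound 3 (beyond the scatter) lie beyond it. Compound 4 `CS(=O)(=O)c1ccc(Cc2n[nH]c(=S)n2/N=C/c2ccccc2F)cc1` differs from compound 2 by fluoro in place of chloro on an aromatic carbon. For the measured compounds named here, no measured step swaps chloro for fluoro; the closest, fluoro added with chloro retained, gave a number 15.1 percentage points higher from compound 2 to compound 3 (beyond the scatter), which does not transfer directly. The step of a number 1.7 percentage points lower from compound 2 to compound 4 (within the scatter) is therefore expected to stay within the scatter. Compound 4 is estimated at 33%, between 20% and 46%.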

Compound 4, a percentage reported as activity, at one concentration (the size of the read-out at that concentration, not a potency): 16.5%
Compound 4: the middle estimate sits 16.5 percentage points above what was measured; the measured number lies below the stated range.
By their numbers in this assay, from the lowest: compound 4; then compounds 1 and 2 (each within the scatter of the next); then compound 3.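

Within the shared core, the halogen on this aryl matters: 2-fluorophenyl in place of 2-chlorophenyl gives a number 18.2 percentage points lower from compound 2 to compound 4 (beyond the scatter), so the gain from adding fluoro with chloro retained does not extend to fluoro replacing chloro. Chloro is also what separates the two fluorinated compounds, with a number 33.3 percentage points lower from compound 3 to compound 4 (beyond the scatter). The 2-fluorophenyl also falls short of the 4-(methylsulfanyl)phenyl, with a number 11.4 percentage points lower from compound 1 to compound 4 (beyond the scatter), leaving compound 4 the weakest of the four in this assay.

No measurement here explains these steps. On these data alone, whether bromo or methoxy on the same aromatic carbon would track chloro or fluoro remains open.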